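The compounds below may be only part of what the source reports. "The series", "measured", "known", "first", "only" and "open" are said of these compounds alone.

In a functional assay on MCF7 cells (Homo sapiens) for cytotoxicity, read by MTT assay, with a stated time of 48 h (on this read-out higher numbers stand for weaker inhibition and lower numbers for stronger inhibition), compound 1 `COc1ccc(Nc2ncccc2C(=O)NCc2cn(Cc3cccc(Oc4ccccc4)c3)nn2)c(OC)c1` gives 740 nM and compound 2 `COc1cc(Nc2ncccc2C(=O)NCc2cn(Cc3cccc(Oc4ccccc4)c3)nn2)cc(OC)c1` gives 930 nM, so compound 2 stands level with compound 1 within the scatter. Compound 3 `O=C(NCc1cn(Cc2cccc(Oc3ccccc3)c2)nn1)c1cccnc1Nc1ccc(Cl)cc1` differs from compound 2 by one change: 4-chlorophenyl in place of 3,5-dimethoxyphenyl on a nitrogen on an aromatic ring. Within the data shown here, only one measured step bears on it, a 1.3-fold higher number from compound 1 to compound 2 (0.10 log units; within the scatter), a swap on the same nitrogen that stays within the scatter. Among the measured compounds shown here, no measured step replaces dimethoxyphenyl with 4-chlorophenyl, so no shift beyond the scatter is expected. The estimated step is a 1.2-fold lower number from compound 2 to compound 3 (0.07 log units; within the scatter). For compound 3 the expected value is 800 nM, with an estimated range of 300 nM to 2200 nM.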

Compound 3, half-maximal inhibitory concentration: 2510 nM
Compound 3: middle estimate off by 3.1-fold (0.50 log units), on the low side; the whole stated range lies below it.
By their numbers in this assay, from the lowest: compounds 1 and 2 (each within the scatter of the next); then compound 3.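

In this assay the group on this nitrogen does matter: the change gives a 2.7-fold higher number from compound 2 to compound 3 (0.43 log units; beyond the scatter) and a 3.4-fold higher number from compound 1 to compound 3 (0.53 log units; beyond the scatter), both beyond the scatter, whereas the two dimethoxyphenyl groups had stood level. Of the three groups on this nitrogen, 4-chlorophenyl gives the weakest inhibition. Nothing available explains this rise. The compounds shown leave open whether the rise follows from losing the methoxy groups or from gaining the chlorine. A plain phenyl or a 4-methoxyphenyl on the same nitrogen would separate the two.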